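The source may hold more compounds than are shown below. What is called first, only, known or untested is meant among the compounds shown, and "the series" means these compounds.

Compound 1 `CCCCCCCCCCCCCCCCCCc1c(O)cc(O)c(C(C)=O)c1O`: 26000 nM
Compound 2 `C=C1CC[C@H]2C(C)(C)CCC[C@]2(C)[C@H]1CC/C(C)=C/Cc1c(O)cc2oc(-c3ccc(O)cc3)c(O)c(=O)c2c1O`: > 100000 nM

Of the compounds shown here, two have been measured in a functional assay on HeLa cells (Homo sapiens) for cytotoxicity, read by XTT assay, with a stated time of 72 h; on this read-out higher numbers stand for weaker inhibition and lower numbers for stronger inhibition. Among the measured compounds shown here, compound 1 gives 26000 nM, the only number among the results. Compound 2 gives only a limit of the assay, > 100000 nM. That is the limit of > 100000 nM in this assay, at which 1 of the 2 values shown sits. For the measured compounds named here, compound 1 therefore stands alone as the one compound with a measured number, with nothing graded to set it against.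

Compound 3 `CCCCCCCC/C=C\CCCCCCCCc1c(O)cc(O)c(C(C)=O)c1O` has not yet been measured. It differs from compound 1 in a single place: dec-1-en-1-yl in place of decyl on a saturated chain carbon, eight bonds along the chain from an aromatic carbon. The rest of the molecule is unchanged.

Going by the values given here, no measured pair of compounds differing in this way is available, so the data give no step size to lean on. In this assay the step of a 1.2-fold lower number from compound 1 to compound 3 (0.07 log units; within the scatter) is expected to be none beyond the usual scatter. Compound 3 is estimated at 22000 nM, with a range from 8000 nM to 60000 nM.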

Compound 3, half-maximal inhibitory concentration: > 100000 nM
Compound 3: no number, only a limit; the forecaster's own chance of this, stated with the estimate: 10%; middle value at least 4.5-fold (0.65 log units) away from the limit.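

In this assay, putting dec-1-en-1-yl in place of decyl, on a saturated chain carbon, eight bonds along the chain from an aromatic carbon, gives an at least 3.8-fold higher number from compound 1 to compound 3 (0.58 log units; beyond the scatter). Among the compounds shown here, this is the first step seen at this position, and it shows that a single double bond outside aromatic rings, with the number of heavy atoms in the group unchanged, is enough to shift the read-out beyond the usual scatter towards weaker inhibition. Compound 3 gives only a limit of the assay, not a number, and that limit recurs among the results: the limit of > 100000 nM in this assay, at which 2 of the 3 values shown sit.

The compounds shown leave open whether the same change would read alike with the double bond elsewhere along the chain, or with the opposite geometry at it. They also leave open how a shorter chain, or an amine or a carboxylic acid on the chain, would read on the shared core.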